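Low cytotoxicity across the series: compound 3 to compound 4

This account rests on a few compounds, and the source may have more. Where it says the series, first, only, none or still open, it means among the compounds named here.

Compound 1 `Cc1ccc(S(=O)(=O)Nc2ccc(-c3nc4ccccc4o3)cc2)cc1`: 88000 nM
Compound 2 `O=S(=O)(Nc1ccc(-c2nc3ccccc3o2)cc1)c1ccc(F)cc1`: > 100000 nM (a limit)
Compound 3 `COc1ccc(S(=O)(=O)Nc2ccc(-c3nc4ccccc4o3)cc2)cc1`: > 100000 nM (a limit)

All three values come from an ADME assay on HEK293 cells (Homo sapiens) for cytotoxicity, read by resazurin assay, with a stated time of 48 h; on this read-out lower numbers stand for higher toxicity in this test and higher numbers for lower toxicity in this test. Compound 3 has no number, only a limit: the limit of > 100000 nM in this assay, at which 2 of the 3 values shown sit. Compound 4 `Cc1ccccc1S(=O)(=O)Nc1ccc(-c2nc3ccccc3o2)cc1` differs from it as follows: 2-methylphenyl in place of 4-methoxyphenyl on a sulfonyl sulfur. The measured steps bearing on this are an at least 1.1-fold higher number from compound 1 to compound 2 (0.05 log units; that floor lies within the scatter) and an at least 1.1-fold higher number from compound 1 to compound 3 (0.05 log units; that floor lies within the scatter). The remaining one is a step that the two limits leave unreadable from compound 2 to compound 3. No step beyond the scatter is therefore expected in this assay. The expected step is an at least 1.1-fold lower number from compound 3 to compound 4 (0.04 log units; that floor lies within the scatter). Going by the values given here, the only actual number, from compound 1 at 88000 nM, anchors the expectation. For compound 4 the estimate is 90000 nM, with an expected range from 45000 nM to 160000 nM.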

Compound 4, half-maximal cytotoxic concentration: > 100000 nM
Compound 4: only a limit was reported; the forecaster's own chance of this, stated with the estimate: 50%; middle value at least 1.1-fold (0.04 log units) away from the limit.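

In this assay, moving the methyl group within the methylphenyl on the sulfonyl sulfur gives an at least 1.1-fold higher number from compound 1 to compound 4 (0.05 log units; that floor lies within the scatter). The steps from compound 2 and compound 3 to compound 4 cannot be read, since both ends of each are limits. On the sulfonyl sulfur, 2-methylphenyl now joins 4-fluorophenyl and 4-methoxyphenyl at the limit: the limit of > 100000 nM in this assay, at which 3 of the 4 values shown sit.

As far as these compounds go, how far compound 2, compound 3 and compound 4 lie past that limit stays open. Also open, from the compounds shown here alone, is whether an amine or a carboxylic acid on this phenyl ring would give a readable number.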